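From methyl to trifluoromethyl on a shared core

The source may report more compounds than this note shows. Statements on the series, on what has been measured and on what is new or still open speak of the compounds shown alone.

Of the compounds shown here, two on a shared core have been measured in a functional assay on Jurkat cells (Homo sapiens) for antiproliferative activity, read by MTT assay, with a stated time of 72 h; on this read-out higher numbers stand for weaker inhibition and lower numbers for stronger inhibition. Compound 1 `CNc1nc(-c2cc(OC)c(OC)c(OC)c2)c(-c2ccc3ccccc3c2)s1` gives 51.1 nM, while compound 2 `CNc1nc(-c2cc(OC)c(OC)c(OC)c2)c(-c2ccc(C)cc2)s1` gives 19 nM, the lower of the two numbers by a gap beyond the usual scatter. Compound 3 `CNc1nc(-c2cc(OC)c(OC)c(OC)c2)c(-c2ccc(C(F)(F)F)cc2)s1` differs from compound 2 by trifluoromethyl in place of methyl on an aromatic carbon. For the measured compounds named here, no measured pair shows this change, so the expectation in this assay is loose. The expected step, a 7.9-fold higher number from compound 2 to compound 3 (0.90 log units; beyond the scatter), is toward weaker inhibition and beyond the scatter. Compound 3 is estimated at 150 nM, with a range of 35 nM to 900 nM.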

Compound 3, half-maximal inhibitory concentration: 3010 nM
The estimate for compound 3 lay 20-fold (1.30 log units) below the measured number; the whole stated range lies below it.
By their numbers in this assay, from the lowest: compound 2; then compound 1; then compound 3.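

In this assay this position on the aromatic ring proves highly sensitive to the group it carries: trifluoromethyl in place of methyl gives a 160-fold higher number from compound 2 to compound 3 (2.20 log units; beyond the scatter), toward much weaker inhibition. For the compounds shown here, the swap changes only this one group, from one heavy atom to four, with no hydrogen-bond donor or acceptor on either side, yet it produces a large step. Nothing at hand explains the size of this loss. Going by these compounds, whether other replacements for methyl here, such as chlorine, an amine or an ethyl chain, would keep the inhibition or lose it stays open.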